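This account rests on a few compounds, and the source may have more. Where it says the series, first, only, none or still open, it means among the compounds named here.

Measured so far in a functional assay on BEL-7404 cells for cytotoxicity against BEL-7404 tumor cell line (Homo sapiens), read by MTT assay, with a stated time of 48 h; a higher number here means a weaker inhibitor, a lower number a stronger inhibitor:
- compound 1, `Cc1ccc2[nH]c(=O)c(-c3nc4cc([N+](=O)[O-])ccc4[nH]3)cc2c1`: compound 1 reports only a limit, > 100000 nM
- compound 2, `O=c1[nH]c2ccccc2cc1-c1nc2cc(F)ccc2[nH]1`: compound 2 gives 27500 nM
- compound 3, `O=c1[nH]c2ccccc2cc1-c1nc2cc(Br)ccc2[nH]1`: compound 3 gives 14500 nM

Compound 3 holds the lowest of the two actual numbers in this assay; its nearest neighbour is compound 2, and the step of a 1.9-fold lower number from compound 2 to compound 3 (0.28 log units; within the scatter) stays within the scatter, so the two cannot be ranked. The value of compound 1 is a limit of this assay and not a number.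

Compound 4, `O=c1[nH]c2ccccc2cc1-c1nc2cc([N+](=O)[O-])ccc2[nH]1`, is not yet measured. It differs from compound 3 in one place: nitro in place of bromo on an aromatic carbon.

For the measured compounds named here, only one measured step exists, a 1.9-fold lower number from compound 2 to compound 3 (0.28 log units; within the scatter), and it is a halogen-for-halogen exchange that changed nothing beyond the scatter. Going by the values given here, no measured step replaces a halogen by nitro on this ring, so that step has no direct precedent here. What the series does show is that compound 1, which carries the same nitro group together with a methyl on the core, sits at the limit of > 100000 nM in this assay, at which 1 of the 3 values shown sits.

On that basis the step of a 3.1-fold higher number from compound 3 to compound 4 (0.49 log units; beyond the scatter) is expected to run toward a higher number in this assay, with a real chance that compound 4 also returns only a limit. The estimate for compound 4 is 45000 nM, with a range of 12000 nM to 150000 nM.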

Compound 4, half-maximal inhibitory concentration: > 100000 nM
Compound 4: no number, only a limit (the forecaster's own chance of this, stated with the estimate: 35%); at least 2.2-fold (0.34 log units) between middle value and limit.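

In this assay compound 4 reports only a limit, > 100000 nM, and not a number. For the compounds shown here, at this aromatic carbon, the change from halogen to nitro gives the first steps beyond the scatter, an at least 6.8-fold higher number from compound 3 to compound 4 (0.83 log units; beyond the scatter) and an at least 3.6-fold higher number from compound 2 to compound 4 (0.56 log units; beyond the scatter), whereas the exchange of one halogen for another, a 1.9-fold lower number from compound 2 to compound 3 (0.28 log units; within the scatter), does not. With the methyl absent, the nitro group still gives no number, so reaching the limit does not require the methyl on the core of compound 1, although the step between compound 1 and compound 4 cannot be read, and both nitro compounds sit at the same point: the limit of > 100000 nM in this assay, at which 2 of the 4 values shown sit.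

The compounds shown leave open whether this drop is specific to nitro or would also appear with other groups on this carbon, such as an amine or a nitrile, and how a plain hydrogen there would compare with the two halogens. Also open, from the compounds shown here alone, are the actual numbers behind the limits of compound 1 and compound 4, so the effect of the methyl in a nitro compound remains unknown.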